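This account rests on a few compounds, and the source may have more. Where it says the series, first, only, none or still open, it means among the compounds named here.

This account follows the step from compound 2 to compound 4 in an ADME assay on Vero cells (Chlorocebus sabaeus) for cytotoxicity, read by luminescence, with a stated time of 2 days; on this read-out lower numbers stand for higher toxicity in this test and higher numbers for lower toxicity in this test. Of the compounds shown here, three sharing one core have been measured. Compound 1 `CCc1nc2ccccc2n1CCCCOc1ccccc1` gives 21 uM. Compound 2 `CCc1nc2ccccc2n1CCCCOc1cccc(C)c1` gives 19 uM, the second highest of the three numbers; its nearest neighbour is compound 1, with a 1.1-fold lower number from compound 1 to compound 2 (0.04 log units; within the scatter), and its furthest is compound 3 `CCc1nc2ccccc2n1CCCCOc1ccc(Cl)cc1F`, which gives 5.7 uM and stands a 3.3-fold lower number from compound 2 to compound 3 (0.52 log units; beyond the scatter) away. Compound 1 to compound 3 shows a 3.7-fold lower number from compound 1 to compound 3 (0.57 log units; beyond the scatter).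

Compound 4 `CCc1nc2ccccc2n1CCCCOc1ccc(C#N)cc1` has not yet been measured. It differs from compound 2 by 4-cyanophenyl in place of 3-methylphenyl on an oxygen on a saturated carbon.

For the measured compounds named here, two measured steps bear on this change. The step from compound 1 to compound 2, a methyl in place of hydrogen, was a 1.1-fold lower number from compound 1 to compound 2 (0.04 log units; within the scatter), so a small change on the aromatic ring moved nothing. The step from compound 2 to compound 3, a different substituted phenyl on the same oxygen, was a 3.3-fold lower number from compound 2 to compound 3 (0.52 log units; beyond the scatter). The change to compound 4 is again a swap of the whole substituted phenyl, so a step toward lower numbers of modest size is expected, though it may stay within the scatter; the expected step is a 1.4-fold lower number from compound 2 to compound 4 (0.13 log units; within the scatter). Compound 4 is therefore estimated at 14 uM, within a range from 7 uM to 28 uM in this assay.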

Compound 4, half-maximal toxic concentration: 27 uM
The estimate for compound 4 lay 1.9-fold (0.29 log units) below the measured number; low and high end bracket the measured number.
By their numbers in this assay, from the lowest: compound 3; then compounds 2, 1 and 4 (each within the scatter of the next).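

In this assay, the nitrile-bearing ring shows that exchanging the whole substituted phenyl on this oxygen need not move the number: 4-cyanophenyl in place of 3-methylphenyl gave a 1.4-fold higher number from compound 2 to compound 4 (0.15 log units; within the scatter) and so stayed with compound 2. Cyano in place of hydrogen on the aromatic carbon behaved alike, with a 1.3-fold higher number from compound 1 to compound 4 (0.11 log units; within the scatter), so among the groups at this position, the unsubstituted phenyl, 3-methylphenyl and 4-cyanophenyl all lie within the scatter of one another. Compound 3 is the one that stands apart, as the contrast with the new group makes plain, with a 4.7-fold higher number from compound 3 to compound 4 (0.68 log units; beyond the scatter), and the drop seen earlier therefore belongs to 4-chloro-2-fluorophenyl rather than to any change of this ring; no measurement shown here gives a reason for that difference.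

Compound 3 carries chlorine and fluorine together, so the compounds shown do not tell which of the two, or only the pair, goes with its lower number. They also leave open whether an amine or a carboxylic acid on this phenyl, or a longer chain in place of the saturated chain, would stay within the same scatter.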